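Clearance notes: methoxyphenyl for chlorophenyl on the shared core

The compounds below may be only part of what the source reports. "The series", "measured", "known", "first", "only" and "open" are said of these compounds alone.

Measured so far:
- compound 1, `COc1ccc(-c2c(S(=O)(=O)c3cccc(F)c3)cnc3cc(F)ccc23)cc1`: 1.89 mL/min
- compound 2, `O=S(=O)(c1cc(Cl)cc(Cl)c1)c1cnc2cc(F)ccc2c1-c1cccc(Cl)c1`: 0.93 mL/min

In an ADME assay on microsomes from liver (Homo sapiens) for metabolic stability, tested at 2.5 uM (on this read-out higher numbers stand for fast clearance and lower numbers for slow clearance), compound 2 gives 0.93 mL/min, the lower of the two numbers, while compound 1 gives 1.89 mL/min, a gap beyond the usual scatter. Among the measured compounds shown here, the two compounds differ in more than one place, so no single step connects them.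

Compound 3, `COc1ccc(-c2c(S(=O)(=O)c3cc(Cl)cc(Cl)c3)cnc3cc(F)ccc23)cc1`, is not yet measured in this assay. It differs from compound 2 by 4-methoxyphenyl in place of 3-chlorophenyl on an aromatic carbon and keeps the rest of compound 2 unchanged.

Compound 3 is expected to move toward faster clearance, with a step of a 1.4-fold higher number from compound 2 to compound 3 (0.15 log units; within the scatter) that stays near the edge of the scatter, because compound 1, which also carries 4-methoxyphenyl at this place, gives 1.89 mL/min. The estimate for compound 3 in this assay is 1.3 mL/min, expected between 0.7 mL/min and 2.4 mL/min.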

Compound 3, intrinsic clearance in a liver preparation (reported as CLH), per the amount of preparation that the assay uses: 1 mL/min
Compound 3: the middle estimate sits 1.3-fold (0.11 log units) above what was measured; measured number inside the range.
By their numbers in this assay, from the lowest: compounds 2, 3 and 1 (each within the scatter of the next, the first and the last beyond it).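

In the read-out of this assay, 4-methoxyphenyl in place of 3-chlorophenyl on the aromatic carbon opposite the ring nitrogen gives a step within the scatter (a 1.1-fold higher number from compound 2 to compound 3 (0.03 log units; within the scatter)), with the 3,5-dichlorophenyl on the sulfonyl sulfur held constant. With 4-methoxyphenyl held constant, 3,5-dichlorophenyl in place of 3-fluorophenyl on the sulfonyl sulfur also stays within the scatter (a 1.9-fold lower number from compound 1 to compound 3 (0.28 log units; within the scatter)), so neither single change on the shared core gives a step beyond it. No measurement at hand bears on the reason for these numbers.

On these data alone, whether a basic amine or a carboxylic acid on the aromatic carbon opposite the ring nitrogen would give a step beyond the scatter remains open. The same holds for a saturated amine ring or a longer alkyl chain on the sulfonyl sulfur.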